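A Trifluoromethyl Added to Compound 2

The compounds below may be only part of what the source reports. "The series", "measured", "known", "first", "only" and "open" are said of these compounds alone.

In a functional assay on PC-3 cells (Homo sapiens) for cytotoxicity, read by MTT assay, with a stated time of 72 h (a lower number here means a stronger inhibitor, a higher number a weaker inhibitor), compound 1 (`O=C(Nc1ccc(Oc2ccnc3[nH]ccc23)cc1)c1nn(-c2ccc(Cl)cc2)ccc1=O`) gives 32400 nM. Compound 2 (`Cn1ccc2c(Oc3ccc(NC(=O)c4nn(-c5ccc(Cl)cc5)ccc4=O)cc3)ccnc21`) gives > 60000 nM, which is a limit of the assay and not a number. Its true position is therefore unknown, and it offers only a floor to build on.

Compound 3 (`Cn1ccc2c(Oc3ccc(NC(=O)c4nn(-c5ccc(Cl)c(C(F)(F)F)c5)ccc4=O)cc3)ccnc21`) keeps all of compound 2 except for one change on the chlorinated ring, where trifluoromethyl replaces hydrogen on an aromatic carbon, ortho to a chloro group: trifluoromethyl in place of hydrogen on an aromatic carbon.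

Within the data shown here, only one measured step exists, an at least 1.8-fold higher number from compound 1 to compound 2 (0.26 log units; that floor lies within the scatter). It is methyl in place of hydrogen on an aromatic nitrogen, a different change at a different place, so it says little about the new one. Among the measured compounds shown here, no measured step tests a substituent on this ring, so neither size nor direction can be read from the data. The expectation in this assay is therefore no clear step beyond the scatter, with the estimate being an at least 1.3-fold lower number from compound 2 to compound 3 (0.12 log units; that floor lies within the scatter). For compound 3 the estimated value is 45000 nM, with an expected range from 14000 nM to 100000 nM.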

Compound 3, half-maximal inhibitory concentration: 10300 nM
For compound 3 the middle estimate is 4.4-fold (0.64 log units) above the measured one; measured number below the stated range.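

In this assay, placing trifluoromethyl on the chlorinated ring gives an at least 5.8-fold lower number from compound 2 to compound 3 (0.76 log units; beyond the scatter). Among these compounds, this shows that the number responds to a change at this position of the ring, which the earlier compounds could not show, as neither of them carries any substituent there other than the chloro group. The step is only a floor, and its true size stays unknown, because the starting value for compound 2 is a limit of the assay and not a number: the limit of > 60000 nM in this assay, at which 1 of the 3 values shown sits.

The compounds shown hold only hydrogen or trifluoromethyl at this position, so it remains open whether the step belongs to trifluoromethyl itself or would also appear with another group here, such as a nitrile or an amine. As far as these compounds go, it also remains open whether the same change would give a similar step on compound 1, which keeps the hydrogen on the aromatic nitrogen, or on a ring without the chloro group.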